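A few compounds are considered here, and "the series" means these few. Any claim that something is new, unique, unknown or untested is made for them only; others in the source may bear on it.

In a functional assay (Homo sapiens) for inhibition of Nucleic Acid, tested at 100 uM (a higher number here means more inhibition at the concentration tested (going by the name of the read-out), a lower number less inhibition), the three measured compounds span a narrow band. Compound 1, `OC[C@H]1O[C@@H](n2cnc3c(Cl)nccc32)C[C@@H]1O`, gives 5% in this assay. Compound 2, `OC[C@H]1O[C@@H](n2cnc3c(SCc4ccccc4)nccc32)C[C@@H]1O`, gives 18%. Compound 3, `OC[C@H]1OC(n2cnc3c(SCc4ccccc4)nccc32)[C@H](O)[C@@H]1O`, gives 30%, the highest of the three numbers, with compound 2 the nearest and compound 1 the furthest, both gaps beyond the scatter.

For the measured compounds named here, only one counted step joins two measured compounds. From compound 2 to compound 1 the change is chloro in place of benzylsulfanyl on an aromatic carbon and the read-out moved by a number 13 percentage points lower from compound 2 to compound 1 (beyond the scatter), a modest step but beyond the scatter.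

Compound 4, `OC[C@H]1OC(n2cnc3c(Cl)nccc32)[C@H](O)[C@@H]1O`, has not yet been measured in this assay. It differs from compound 3 by chloro in place of benzylsulfanyl on an aromatic carbon. The same change separates compound 2 from compound 1, and the place is described in the same words in both cases, so it is the same change made twice among these four compounds. How the core of compound 3 differs from the core of compound 2 is not broken down here.

The expected step, a number 13 percentage points lower from compound 3 to compound 4 (beyond the scatter), rests on compound 2 and compound 1 because a number 13 percentage points lower from compound 2 to compound 1 (beyond the scatter) is what the same change gave there. Compound 4 is therefore expected to give about 17% in this assay, most likely between 5% and 30%.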

Compound 4, a percentage reported as inhibition, at one concentration (the size of the read-out at that concentration, not a potency): 76%
Compound 4: middle estimate off by 59 percentage points, on the low side; the whole stated range lies below it.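

In this assay, replacing benzylsulfanyl with chloro on the aromatic carbon does not behave as one transferable change across the two cores, and the result from one pair gives no usable guide to the other: the same change on two cores in this assay, a number 13 percentage points lower (beyond the scatter) from compound 2 to compound 1 and a number 46 percentage points higher (beyond the scatter) from compound 3 to compound 4, 59 percentage points apart, beyond the scatter of two such steps The new step, a number 46 percentage points higher from compound 3 to compound 4 (beyond the scatter), is large and runs in the opposite direction to the earlier one, so within these four compounds the outcome of the exchange depends on the core that carries it. This does not show which feature of the core is responsible, as the difference between the two cores is not broken down here, and two pairs set no rule for any further core in the series.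

The compounds shown leave open how other groups would behave on the same aromatic carbon, for example an amine, a methoxy group or a shorter methylsulfanyl chain, and whether such groups would also give opposite results on the two cores. They also leave open whether the chloro compound on the core of compound 3 stands alone in this series or marks a wider trend among small groups at that place.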